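Azole replacement at the branched carbon: compound 3 to compound 4

The source may hold more compounds than are shown below. What is called first, only, known or untested is meant among the compounds shown, and "the series" means these compounds.

Compound 3 `Cc1nc(C(c2ccc(-c3ccc4cccc(F)c4c3)[nH]c2=O)C(C)C)[nH]c1C` gives 7 nM in an assay on CHO cells for displacement of a labelled ligand from prostaglandin E2 receptor EP3 subtype (Homo sapiens), read by radioligand binding (a lower number here means a stronger inhibitor, a higher number a weaker inhibitor), the lowest of the three numbers; compound 1 `CC(C)C(Cc1ncc[nH]1)c1ccc(-c2ccc3cccc(F)c3c2)[nH]c1=O` gives 11 nM and compound 2 `CC(C)C(c1ncco1)c1ccc(-c2ccc3cccc(F)c3c2)[nH]c1=O` gives 24 nM. The step of a 1.6-fold lower number from compound 1 to compound 3 (0.20 log units; within the scatter) lies within the scatter, whereas a 3.4-fold lower number from compound 2 to compound 3 (0.54 log units; beyond the scatter) is beyond it, as is a 2.2-fold higher number from compound 1 to compound 2 (0.34 log units; beyond the scatter). Compound 4 `CC(C)C(Nc1nccs1)c1ccc(-c2ccc3cccc(F)c3c2)[nH]c1=O` carries (1,3-thiazol-2-yl)amino in place of 4,5-dimethyl-1H-imidazol-2-yl on a saturated chain carbon bound to an aromatic carbon and a saturated chain carbon. The entering group resembles compound 2 in lacking the ring hydrogen-bond donor, and compound 1 in placing a single-atom link before the ring; both of those compounds sit above compound 3. A modest weakening in this assay is therefore expected, estimated as a 2.6-fold higher number from compound 3 to compound 4 (0.41 log units; beyond the scatter). Compound 4 is estimated at 18 nM, with a range of 6 nM to 55 nM.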

Compound 4, inhibition constant: 9.4 nM
Compound 4: the middle estimate sits 1.9-fold (0.28 log units) above what was measured; the range from low to high includes it.
By their numbers in this assay, from the lowest: compounds 3, 4 and 1 (each within the scatter of the next); then compound 2.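

In this assay, (1,3-thiazol-2-yl)amino on this saturated chain carbon stays level with the 4,5-dimethyl-1H-imidazol-2-yl group (a 1.3-fold higher number from compound 3 to compound 4 (0.13 log units; within the scatter)) and the (1H-imidazol-2-yl)methyl group (a 1.2-fold lower number from compound 1 to compound 4 (0.07 log units; within the scatter)), so this position tolerates a sulfur-containing ring attached through an amino nitrogen. The 1,3-oxazol-2-yl group of compound 2 alone stands apart (a 2.6-fold lower number from compound 2 to compound 4 (0.41 log units; beyond the scatter)). No measurement shown accounts for these differences.

Open, on these data alone, is whether the thiazole ring or the amino link carries the result, since the two change together here. Also open, as far as these compounds go, is how a carboxylic acid, a primary amine or a longer alkyl chain would fare at this carbon.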